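The source may hold more compounds than are shown below. What is called first, only, known or untested is meant among the compounds shown, and "the series" means these compounds.

Compound 1 `COc1ccc(/C=N/NC(=O)c2cc(-c3ccc(Cl)cc3)nn2Cc2ccc(Cl)nc2)cc1` and compound 2 `COc1ccc(/C=N/NC(=O)c2cc(-c3ccc(OC)cc3)nn2Cc2ccc(Cl)nc2)cc1` share one core and differ in a single place: methoxy in place of chloro on an aromatic carbon. In a functional assay on A549 cells (Homo sapiens) for cytotoxicity, read by MTT assay, with a stated time of 48 h (on this read-out higher numbers stand for higher solubility and lower numbers for lower solubility), compound 1 gives 3300 nM, and compound 2 gives 17500 nM, so the change made a step of a 5.3-fold higher number from compound 1 to compound 2 (0.72 log units; beyond the scatter). Compound 3 `O=C(N/N=C/c1ccccc1O)c1cc(-c2ccc(Cl)cc2)nn1Cc1ccccc1` is built on another core; how the two cores differ is not broken down here. In this assay compound 3 gives 25000 nM, a number close to that of compound 2 and well apart from that of compound 1. Compound 4 `COc1ccc(-c2cc(C(=O)N/N=C/c3ccccc3O)n(Cc3ccccc3)n2)cc1` stands to compound 3 as compound 2 stands to compound 1: methoxy in place of chloro on an aromatic carbon, at the same place, so this is the same change. Because the step of a 5.3-fold higher number from compound 1 to compound 2 (0.72 log units; beyond the scatter) lay beyond the usual scatter, the same change is expected to raise the number again, while the other core leaves room for a somewhat different size. The expected step from compound 3 to compound 4 is a 3.2-fold higher number from compound 3 to compound 4 (0.51 log units; beyond the scatter). Compound 4 is therefore estimated at 80000 nM, likely between 30000 nM and 250000 nM.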

Compound 4, solubility: 23000 nM
Estimate against measurement, compound 4: 3.5-fold (0.54 log units) above, and the stated range ends above it.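

On the second core, the same change from 4-chlorophenyl to 4-methoxyphenyl gives a 1.1-fold lower number from compound 3 to compound 4 (0.04 log units; within the scatter) in this assay, so the rise seen on the first core does not return. The two steps do not match: the same change on two cores in this assay, a 5.3-fold higher number (0.72 log units; beyond the scatter) from compound 1 to compound 2 and a 1.1-fold lower number (0.04 log units; within the scatter) from compound 3 to compound 4, 5.8-fold (0.76 log units) apart, beyond the scatter of two such steps
So in this series, the size of this step did not carry over from one core to the other, but two pairs cannot show why, and they give no rule for any further core.

The compounds shown leave open whether another group at the same place, such as an amine or a carboxylic acid, would give matching steps on both cores. They also leave open which difference between the two cores matters.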